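From Piperidine Back to an Arylamino Group

The source may report more compounds than this note shows. Statements on the series, on what has been measured and on what is new or still open speak of the compounds shown alone.

In a functional assay on MGC-803 cells (Homo sapiens) for inhibition, read by sulforhodamine B assay (on this read-out higher numbers stand for weaker inhibition and lower numbers for stronger inhibition), compound 1 `O=C1C=C(Nc2ccccc2)C(=O)c2c1nc1n2[C@H]2OC[C@@H](O)[C@H]2OC1` gives 1730 nM. Compound 2 `O=C1C=C(N2CCCCC2)C(=O)c2c1nc1n2[C@H]2OC[C@@H](O)[C@H]2OC1` reaches only a limit of the assay, > 8000 nM. Compound 3 `COc1cccc(NC2=CC(=O)c3nc4n(c3C2=O)[C@H]2OC[C@@H](O)[C@H]2OC4)c1` differs from compound 2 by (3-methoxyphenyl)amino in place of piperidin-1-yl on a double-bonded ring carbon, with (3-methoxyphenyl)amino in place of piperidin-1-yl on a double-bonded ring carbon. Going by the values given here, the one measured step that bears on this change is an at least 4.6-fold higher number from compound 1 to compound 2 (0.66 log units; beyond the scatter), where piperidin-1-yl replaced anilino. Read in reverse, that step leads to the expectation of a lower number in this assay for compound 3, of at least similar size. The expected change is an at least 4.4-fold lower number from compound 2 to compound 3 (0.64 log units; beyond the scatter). The estimate for compound 3 is 1800 nM, within an expected range of 700 nM to 5000 nM.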

Compound 3, half-maximal inhibitory concentration: 1780 nM
Compound 3: the middle estimate sits 1.0-fold (0.00 log units) above what was measured; the measured number falls inside the stated range.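

In this assay, a second arylamino group on this double-bonded ring carbon again separates from piperidin-1-yl, with an at least 4.4-fold lower number from compound 2 to compound 3 (0.65 log units; beyond the scatter). Methoxy in place of hydrogen on the aromatic ring gives a 1.0-fold higher number from compound 1 to compound 3 (0.01 log units; within the scatter), so compound 1 and compound 3 cannot be told apart here. The first step remains only a bound, because compound 2 stands at a limit of the assay: the limit of > 8000 nM in this assay, at which 1 of the 3 values shown sits.

Left open is how a benzylamino group, a morpholin-4-yl group or a chloro-substituted anilino group would read on this carbon.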